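Carboxy to (phenylsulfonyl)carbamoyl in compound 3

This account rests on a few compounds, and the source may have more. Where it says the series, first, only, none or still open, it means among the compounds named here.

- compound 1 `COc1cc(C(=O)NS(=O)(=O)c2ccccc2)ccc1Cc1cn(C2CCCC2)c2ccc(NC(=O)OC3CCCC3)cc12` gives 7.84
- compound 2 `CCCn1cc(Cc2ccc(C(=O)O)cc2OC)c2cc(NC(=O)OC3CCCC3)ccc21` gives 7.72

Both values come from an ADME assay for acid dissociation (a higher number here means a more potent compound, by a factor of ten per unit of this negative logarithm, a lower number a less potent compound), and lie within the scatter of each other, so no order can be read between compound 2 and compound 1.

Compound 3 `CCCn1cc(Cc2ccc(C(=O)NS(=O)(=O)c3ccccc3)cc2OC)c2cc(NC(=O)OC3CCCC3)ccc21` departs from compound 2 in one place: (phenylsulfonyl)amino in place of hydroxy on a carbonyl carbon with (phenylsulfonyl)amino in place of hydroxy on a carbonyl carbon. For the measured compounds named here, no step between measured compounds shows this change. Compound 1 also carries (phenylsulfonyl)carbamoyl and gives 7.84 within the scatter of compound 2, so only a small upward step in this assay is expected, near the scatter. The estimated step is a number 0.28 log units higher from compound 2 to compound 3 (within the scatter) on this reading. Compound 3 is expected at 8 with an estimated range from 7.5 to 8.6 in this assay.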

Compound 3, negative logarithm of the antagonist equilibrium constant: 8.44
Estimate against measurement, compound 3: 0.44 log units below; measured number inside the range.
By their numbers in this assay, from the lowest: compounds 2 and 1 (each within the scatter of the next); then compound 3.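

In this assay, for the compounds shown here, (phenylsulfonyl)amino in place of hydroxy on a carbonyl carbon gives a number 0.72 log units higher from compound 2 to compound 3 (beyond the scatter), the first reading of this change in a single place. With (phenylsulfonyl)carbamoyl held constant, propyl in place of cyclopentyl on an aromatic nitrogen gives a number 0.60 log units higher from compound 1 to compound 3 (beyond the scatter), so the substituent on that nitrogen also shifts the number, which the earlier pair, differing in two places, could not show. The data shown give no basis for explaining either step.

On these data alone, how the number responds to methyl in place of the phenyl on the sulfonyl, or to a butyl chain on the aromatic nitrogen, remains open. Also open, as far as these compounds go, is whether carboxy to (phenylsulfonyl)carbamoyl gives a step of the same size with cyclopentyl on the aromatic nitrogen.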